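Bromo in place of fluoro: compound 3 to compound 4

The source may report more compounds than this note shows. Statements on the series, on what has been measured and on what is new or still open speak of the compounds shown alone.

In a functional assay on KYSE-450 cells (Homo sapiens) for inhibition, read by CCK-8 assay, with a stated time of 48 h (on this read-out higher numbers stand for weaker inhibition and lower numbers for stronger inhibition), compound 1 `COc1cc(N(Cc2ccc(Cl)cc2)C(=O)CSC(=S)N2CCN(C(=O)OC(C)(C)C)CC2)cc(OC)c1OC`, carrying 4-chlorophenyl, gives 11900 nM. Compound 2 `COc1ccc(CN(C(=O)CSC(=S)N2CCN(C(=O)OC(C)(C)C)CC2)c2cc(OC)c(OC)c(OC)c2)cc1OC`, carrying 3,4-dimethoxyphenyl, reads > 20000 nM, which is a limit of the assay and not a number. Compound 3 `COc1ccc(CN(C(=O)CSC(=S)N2CCN(C(=O)OC(C)(C)C)CC2)c2cc(OC)c(OC)c(OC)c2)cc1F`, carrying 3-fluoro-4-methoxyphenyl, gives 2410 nM, the lower of the two actual numbers in the series, with a 4.9-fold lower number from compound 1 to compound 3 (0.69 log units; beyond the scatter).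

Compound 4 `COc1ccc(CN(C(=O)CSC(=S)N2CCN(C(=O)OC(C)(C)C)CC2)c2cc(OC)c(OC)c(OC)c2)cc1Br` differs from compound 3 in one place: bromo in place of fluoro on an aromatic carbon. This puts bromo in place of fluoro on an aromatic carbon, ortho to a methoxy group.

The closest measured change sits on that same carbon: an at least 8.2-fold lower number from compound 2 to compound 3 (0.91 log units; beyond the scatter). This is fluoro in place of methoxy, and its size is only a floor, given the limit on one side. It shows that the read-out in this assay can move strongly with this substituent. Among the compounds with values here, no measured compound carries bromo, and no measured step exchanges one halogen for another, so the data fix the direction only loosely. Within the data shown here, compound 3 holds the lowest number so far, which leans the expectation toward a higher number. The expected change is small: a 1.7-fold higher number from compound 3 to compound 4 (0.22 log units; within the scatter). The estimate for compound 4 is 4000 nM, with an expected range of 1200 nM to 14000 nM.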

Compound 4, half-maximal inhibitory concentration: 1850 nM
The estimate for compound 4 lay 2.2-fold (0.33 log units) above the measured number; measured number inside the range.
By their numbers in this assay, from the lowest: compounds 4 and 3 (each within the scatter of the next); then compound 1. At a limit, above all of these: compound 2.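

Bromo and fluoro cannot be told apart on this aromatic carbon, ortho to a methoxy group, in this assay (a 1.3-fold lower number from compound 3 to compound 4 (0.11 log units; within the scatter)), which is the first halogen-for-halogen exchange in the series and leaves the two compounds level within the scatter. The 3-bromo-4-methoxyphenyl group also stands clear of 4-chlorophenyl on the same nitrogen (a 6.4-fold lower number from compound 1 to compound 4 (0.81 log units; beyond the scatter)), so the separation first seen with the 3-fluoro-4-methoxyphenyl group holds with a second halogen on this carbon. Bromo in place of methoxy on this carbon repeats the large shift seen with fluoro (an at least 10-fold lower number from compound 2 to compound 4 (1.03 log units; beyond the scatter)), but this size is only a floor, as compound 2 stands at a limit of the assay and not at a number: the limit of > 20000 nM in this assay, at which 1 of the 4 values shown sits.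

The compounds shown leave open how chloro, or a non-halogen group such as an amine or a carboxylic acid, would read on this carbon, so the tolerance of the position is known for only two halogens and one methoxy group. They also leave open whether the 4-methoxy group is needed for either halogen to hold its reading, and whether a plain hydrogen on this carbon would read with the halogens or with the methoxy compound.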